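The source may hold more compounds than are shown below. What is called first, only, known or untested is meant among the compounds shown, and "the series" means these compounds.

Three compounds share one core, and only one of them has a number against it. Compound 1 `Oc1cccc(-c2cc(-c3cccnc3)nc(-c3cccc(Cl)c3)c2)c1` carries a 3-chlorophenyl group and a pyridin-3-yl group, and in a functional assay on DU-145 cells (Homo sapiens) for cytotoxicity, read by CCK-8 assay and cell counting, with a stated time of 2 days (on this read-out higher numbers stand for weaker inhibition and lower numbers for stronger inhibition), compound 1 stands at "not determined" (no result reported), with no result reported for it. Compound 2 `Oc1cccc(-c2cc(-c3ccc(Cl)cc3)nc(-c3ccsc3)c2)c1` carries a 4-chlorophenyl group and a thiophen-3-yl group, and in this assay compound 2 gives 11600 nM. That value is the only one shown in this assay; the remaining entry stands without a number, so compound 2 has no measured neighbour to be set against.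

Compound 3 `Oc1cccc(-c2cc(-c3ccsc3)nc(-c3cccc(Cl)c3)c2)c1` keeps every atom of compound 2 but joins them differently: 3-chlorophenyl in place of 4-chlorophenyl on an aromatic carbon. Within the data shown here, the chlorine moves within the same ring while the rest of the molecule is unchanged, and nothing among the measured compounds shows what such a shift does in this assay.

Without a measured step to lean on, the author expects compound 3 to land close to compound 2, with a step of no change at the digits printed from compound 2 to compound 3 (within the scatter) that is not expected to go beyond the usual scatter in either direction. Compound 3 is therefore estimated at 11600 nM in this assay, within a range from 4000 nM to 35000 nM.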

Compound 3, half-maximal inhibitory concentration: 3330 nM
The estimate for compound 3 lay 3.5-fold (0.54 log units) above the measured number; measured number outside the range, below it.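

In this assay the chlorine shift gives a 3.5-fold lower number from compound 2 to compound 3 (0.54 log units; beyond the scatter) and is the first measured step among these compounds, showing that the place of the chlorine on this ring matters even though the two compounds hold the same atoms. On this read-out the lower number stands for stronger inhibition, so 3-chlorophenyl on the aromatic carbon next to the ring nitrogen does modestly better than 4-chlorophenyl, with the thiophen-3-yl group and the 3-hydroxyphenyl group unchanged. The compounds shown offer no measured property or other outside finding that accounts for this difference.

On these data alone, compound 1, which pairs 3-chlorophenyl with pyridin-3-yl, stands at "not determined" (no result reported) in this read-out, so the step between it and compound 3 cannot be read and the part played by the thiophen-3-yl group remains unknown. Also open, as far as these compounds go, is how the same position would respond to a methoxy group, an amine or a carboxylic acid in place of the chlorine, and whether this one chlorine shift would hold on other versions of the shared core.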